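The source may hold more compounds than are shown below. What is called first, only, known or untested is meant among the compounds shown, and "the series" means these compounds.

In a functional assay on M21 cells (Homo sapiens) for antiproliferative activity, read by sulforhodamine B assay, with a stated time of 48 h (on this read-out higher numbers stand for weaker inhibition and lower numbers for stronger inhibition), compound 1 (`CCc1ccccc1OS(=O)(=O)c1ccc(N2CCN(C)C2=O)cc1`) gives 2300 nM, and compound 2 (`CCN1CCN(c2ccc(S(=O)(=O)Oc3cccc(OC)c3)cc2)C1=O`) gives 7000 nM. Compound 3 (`CCCN1CCN(c2ccc(S(=O)(=O)Oc3ccccc3CC)cc2)C1=O`) gives > 50000 nM, which is a limit and not a number; it stands at the limit of > 50000 nM in this assay, at which 1 of the 3 values shown sits. Compound 4 (`CCCN1CCN(c2ccc(S(=O)(=O)Oc3cccc(C)c3)cc2)C1=O`) keeps the chain of compound 3 and has 3-methylphenyl in place of 2-ethylphenyl on an oxygen. Within the data shown here, the only measured step, an at least 21-fold higher number from compound 1 to compound 3 (1.33 log units; beyond the scatter), is large and beyond the scatter, but it changes the chain, not the group on oxygen. That chain stays, so weak inhibition is expected to persist in this assay. The expected change is an at least 2.5-fold lower number from compound 3 to compound 4 (0.39 log units; beyond the scatter), a modest estimated move toward a lower number. For compound 4 the estimate is 20000 nM, with an expected range of 6000 nM to 50000 nM.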

Compound 4, half-maximal inhibitory concentration: 28000 nM
Compound 4: the middle estimate sits 1.4-fold (0.15 log units) below what was measured; low and high end bracket the measured number.
By their numbers in this assay, from the lowest: compound 1; then compound 2; then compound 4. At a limit, above all of these: compound 3.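

With the chain of compound 3 kept, 3-methylphenyl in place of 2-ethylphenyl on an oxygen gives an at least 1.7-fold lower number from compound 3 to compound 4 (0.25 log units; that floor lies within the scatter). The group on this oxygen can therefore bring a value under the limit in this assay, although the floor of this step alone does not clear the scatter. The value of compound 3 remains a limit, so the true size of the step is unknown: the limit of > 50000 nM in this assay, at which 1 of the 4 values shown sits.

Open, from the compounds shown here alone, is how 3-methylphenyl behaves with the chain of compound 1. Also open, going by these compounds, is what an amine or a carboxylic acid would do on the group on this oxygen.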